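Benzylamino in Place of Aryl Amino: Expected Activity

The compounds below may be only part of what the source reports. "The series", "measured", "known", "first", "only" and "open" are said of these compounds alone.

Measured compounds:
compound 1, `CCCCCOC1=C(C(=O)c2ccccc2)C(c2ccc(Br)cc2)N(CCCn2ccnc2)C1=O`, 9990 nM
compound 2, `O=C(C1=C(Nc2ccccc2)C(=O)N(CCCn2ccnc2)C1c1ccc(Br)cc1)c1ccccc1`, 24400 nM
compound 3, `O=C(C1=C(Nc2ccc(OC(F)(F)F)cc2)C(=O)N(CCCn2ccnc2)C1c1ccc(Br)cc1)c1ccccc1`, 17900 nM

In a functional assay on SAOS-2 cells (Homo sapiens) for antiproliferative activity, read by MTT assay, with a stated time of 72 h (on this read-out higher numbers stand for weaker inhibition and lower numbers for stronger inhibition), compound 3 stands second highest of the three numbers. Its nearest neighbour is compound 2, a 1.4-fold lower number from compound 2 to compound 3 (0.13 log units; within the scatter); the furthest is compound 1, a 1.8-fold higher number from compound 1 to compound 3 (0.25 log units; within the scatter). Compound 4, `O=C(C1=C(NCc2ccccc2)C(=O)N(CCCn2ccnc2)C1c1ccc(Br)cc1)c1ccccc1`, differs from compound 3 by benzyl in place of 4-(trifluoromethoxy)phenyl on an amine nitrogen. Among the measured compounds shown here, the steps that bear on this change are the replacements at the same double-bonded ring carbon: a 2.4-fold higher number from compound 1 to compound 2 (0.39 log units; beyond the scatter), and a 1.8-fold higher number from compound 1 to compound 3 (0.25 log units; within the scatter). Both are small, one modest and one within the scatter. The account therefore expects no step beyond the scatter for compound 4, a 1.0-fold higher number from compound 3 to compound 4 (0.00 log units; within the scatter). Compound 4 is estimated at 18000 nM, with a range from 8000 nM to 40000 nM.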

Compound 4, half-maximal inhibitory concentration: 31600 nM
Beside the measured number, compound 4's estimate is 1.8-fold (0.24 log units) below it; low and high end bracket the measured number.
By their numbers in this assay, from the lowest: compounds 1, 3, 2 and 4 (each within the scatter of the next, the first and the last beyond it).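

In this assay benzyl in place of 4-(trifluoromethoxy)phenyl on the amine nitrogen gives (a 1.8-fold higher number from compound 3 to compound 4 (0.25 log units; within the scatter)) and benzyl in place of phenyl gives (a 1.3-fold higher number from compound 2 to compound 4 (0.11 log units; within the scatter)), so neither aryl group stands apart from benzyl on this nitrogen. Benzylamino in place of pentyloxy on the double-bonded ring carbon gives (a 3.2-fold higher number from compound 1 to compound 4 (0.50 log units; beyond the scatter)), a step beyond the scatter, as with the anilino of compound 2 but not the substituted anilino of compound 3. No measurement shown here accounts for these steps. The compounds shown leave open whether the gap from compound 1 follows the ether oxygen or the pentyl chain, which a pentylamino group on that carbon would separate.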